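Swapping thiophen-2-yl for 4-fluorobenzyl: working notes

The source may report more compounds than this note shows. Statements on the series, on what has been measured and on what is new or still open speak of the compounds shown alone.

Measured in (a functional assay on HL-60 cells (Homo sapiens) for inhibition, read by CCK-8 assay, with a stated time of 48 h; on this read-out higher numbers stand for weaker inhibition and lower numbers for stronger inhibition):
Compound 1 (`Cc1ccc(S(=O)(=O)Oc2ccccc2/C=C(\C#N)C(=O)Nc2nnc(C)s2)cc1`) gives (11500 nM)
Compound 2 (`COc1ccc(S(=O)(=O)Oc2ccccc2/C=C(\C#N)C(=O)Nc2nnc(-c3cccs3)s2)cc1`) gives (5230 nM)

Compound 2 has the lower number of the two, and its gap to compound 1 lies beyond the scatter. For the measured compounds named here, these two compounds differ in more than one place, and the series holds no measured step at a single place.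

Compound 3 (`COc1ccc(S(=O)(=O)Oc2ccccc2/C=C(\C#N)C(=O)Nc2nnc(Cc3ccc(F)cc3)s2)cc1`) is still unmeasured. It follows from compound 2 by one change (4-fluorobenzyl in place of thiophen-2-yl on an aromatic carbon): 4-fluorobenzyl in place of thiophen-2-yl on an aromatic carbon.

Going by the values given here, with no measured precedent for this exchange, no step beyond the scatter is expected in (this assay), and no direction can be favoured. The estimate therefore stays close to compound 2 (5230 nM). The expected change is small, an estimated (a 1.0-fold lower number from compound 2 to compound 3 (0.02 log units; within the scatter)).

The estimated value for compound 3 is (5000 nM), with an expected range from (1700 nM) to (14000 nM).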

Compound 3, half-maximal inhibitory concentration: 4050 nM
Compound 3: the middle estimate sits 1.2-fold (0.09 log units) above what was measured; the range from low to high includes it.
By their numbers in this assay, from the lowest: compounds 3 and 2 (each within the scatter of the next); then compound 1.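

In this assay, for the compounds shown here, the exchange of thiophen-2-yl for 4-fluorobenzyl gives a 1.3-fold lower number from compound 2 to compound 3 (0.11 log units; within the scatter) and is the first step that can be read at a single place. On the aromatic carbon that carries these groups, a five-membered aromatic ring with one hetero atom and a 4-fluorobenzyl group with its six-membered carbon ring therefore give values within the scatter of each other. Nothing available explains this outcome.

On these data alone, whether an amine, a carboxylic acid or a longer alkyl chain on this carbon would also stay within the scatter of compound 3 remains open. Compound 1 differs from compound 2 in more than one place, so its gap to compound 2 cannot be assigned to any one change, and the effect of the other substituent on the core remains unresolved.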